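This account rests on a few compounds, and the source may have more. Where it says the series, first, only, none or still open, it means among the compounds named here.

Three compounds share the same core here, a chain with a carbonyl that links a phenyl ring to a pyrazole bearing a second aryl group. In a functional assay on SN12C cells (Homo sapiens) for cytotoxicity, read by sulforhodamine B assay, with a stated time of 48 h, tested at 100 uM (on this read-out higher numbers stand for a weaker effect at the one concentration tested and lower numbers for a stronger effect), compound 3 `COc1ccc(C(=O)/C=C/c2cc(-c3cc(OC)c(OC)c(OC)c3)n[nH]2)cc1OC` gives -86%, the lowest of the three numbers. Compound 1 `COc1ccc(-c2cc(/C=C/C(=O)c3cc(OC)c(OC)c(OC)c3)[nH]n2)cc1OC` gives -67%, and compound 2 `COc1ccc(C(=O)/C=C/c2cc(-c3cc(OC)c(OC)c(OC)c3)n[nH]2)cc1` gives 7%. Among the compounds with values here, only the step from compound 2 to compound 3 is a single change, and it reads a number 93 percentage points lower from compound 2 to compound 3 (beyond the scatter).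

Compound 4 `COc1cc(C(=O)/C=C/c2cc(-c3cc(OC)c(OC)c(OC)c3)n[nH]2)cc(OC)c1OC` is still unmeasured and arises from compound 3 by a single change, (methoxy in place of hydrogen on an aromatic carbon). The same kind of change, a methoxy in place of a hydrogen on an aromatic carbon, is exactly what separates compound 2 from compound 3, and there it produced a large step toward stronger effect. Compound 4 is therefore expected to keep at least the strong effect of compound 3, with a further step of a number 1 percentage points higher from compound 3 to compound 4 (within the scatter) that most likely stays within the scatter of the method, because compound 3 already reads -86% and little room for a lower number remains. In this assay compound 4 is estimated at -85%, with a range from -100% to -45%.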

Compound 4, a percentage reported as activity, at one concentration (the size of the read-out at that concentration, not a potency): -97%
Compound 4: middle estimate off by 12 percentage points, on the high side; measured number inside the range.
By their numbers in this assay, from the lowest: compound 4; then compound 3; then compound 1; then compound 2.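

In this assay, the new methoxy sits ortho to a methoxy group and meta to a second one, and the step reads a number 11 percentage points lower from compound 3 to compound 4 (beyond the scatter). So even on a ring that already carries two methoxy groups, one more still pushes the number down, although compound 3 had left little room for a stronger effect. The same swap made on the other aryl group, on the way to compound 4, reads a number 30 percentage points lower from compound 1 to compound 4 (beyond the scatter), and taken with the earlier step it shows that this change does not bring a fixed gain, its size differing from one core to the other: the same change on two cores in this assay, a number 93 percentage points lower (beyond the scatter) from compound 2 to compound 3 and a number 30 percentage points lower (beyond the scatter) from compound 1 to compound 4, 63 percentage points apart, beyond the scatter of two such steps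

The compounds shown leave open whether the gain belongs to the methoxy itself or would also come with another group in the same place, such as a hydroxyl, an ethoxy or a fluorine atom. They also leave open how potency compares across the series, since each number is the size of the effect at one concentration in one cell line.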